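Working notes: from compound 3 to compound 4

This account rests on a few compounds, and the source may have more. Where it says the series, first, only, none or still open, it means among the compounds named here.

Compound 3 `Oc1cc(C(F)(F)F)ccc1-c1nc(-c2ccccc2O)n(-c2ccc(C(F)(F)F)cc2)n1` gives 90.5% in a functional assay on PC-12 cells (Rattus norvegicus) for cytotoxicity, read by MTT assay, with stated times of 2 h and 24 h, tested at 5 uM; a higher number here means a stronger effect of the compound at the concentration tested, a lower number a weaker effect. On the three numbers shown it stands second highest: compound 2 `Oc1cc(C(F)(F)F)ccc1-c1nc(-c2ccccc2O)n(-c2ccc(Cl)cc2)n1` gives 87.3% and compound 1 `CC(C)c1ccc(-n2nc(-c3ccc(C(F)(F)F)cc3O)nc2-c2ccccc2O)cc1` gives 100%, with a number 3.2 percentage points higher from compound 2 to compound 3 (within the scatter) and a number 9.5 percentage points lower from compound 1 to compound 3 (within the scatter). Only a number 12.7 percentage points lower from compound 1 to compound 2 (beyond the scatter) lies beyond the scatter. Compound 4 `Oc1cc(C(F)(F)F)ccc1-c1nc(-c2ccccc2O)n(-c2cccc(F)c2)n1` differs by 3-fluorophenyl in place of 4-(trifluoromethyl)phenyl on an aromatic nitrogen. All three measured steps exchange the group on that same aromatic nitrogen, and across them the values move little. Within the data shown here, no measured step brings in 3-fluorophenyl, so that narrowness is the only guide. A step within the scatter is expected, a number 2.5 percentage points lower from compound 3 to compound 4 (within the scatter), and the estimate for compound 4 is 88%, expected to lie between 78% and 97%.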

Compound 4, a percentage reported as activity, at one concentration (the size of the read-out at that concentration, not a potency): 87.7%
For compound 4 the middle estimate is 0.3 percentage points above the measured one, and the stated range covers the measured number.
By their numbers in this assay, from the lowest: compounds 2, 4, 3 and 1 (each within the scatter of the next, the first and the last beyond it).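

Among these compounds, on the aromatic nitrogen, 3-fluorophenyl is the first group that is not a 4-substituted phenyl, and in this assay it gives a number 2.8 percentage points lower from compound 3 to compound 4 (within the scatter) and a number 0.4 percentage points higher from compound 2 to compound 4 (within the scatter). Against 4-isopropylphenyl the change gives a number 12.3 percentage points lower from compound 1 to compound 4 (beyond the scatter), so compound 2 and compound 4 both lie beyond the scatter from compound 1. Nothing measured gives a reason for these values.

As far as these compounds go, only phenyl groups bearing chloro, fluoro, trifluoromethyl or isopropyl appear on this nitrogen, so a carboxylic acid or an amine on that phenyl remains open. Readings at a single concentration also leave potency open.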